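Notes on the benzyl ring change from compound 3 to compound 4

The compounds below may be only part of what the source reports. "The series", "measured", "known", "first", "only" and "open" are said of these compounds alone.

Compound 3 `Cc1cccc(CSc2cc(Cl)c(C)cc2S(=O)(=O)/N=C(\N)n2nc(C)cc2-c2ccccc2)c1` gives 0.214 h in an ADME assay on microsomes from liver (Homo sapiens) for metabolic stability, read by LC-MS, using NADPH, tested at 5 uM; on this read-out lower numbers stand for a shorter-lived compound and higher numbers for a longer-lived compound. Compound 1 `Cc1cccc(CSc2cc(Cl)c(C)cc2S(=O)(=O)/N=C(\N)n2nccc2-c2ccccc2)c1` gives 0.232 h in this assay. Compound 2 `Cc1cc(-c2ccccc2)n(/C(N)=N/S(=O)(=O)c2cc(C)c(Cl)cc2SCc2cccc3ccccc23)n1` gives 0.256 h. The three numbers sit together: a 1.1-fold lower number from compound 1 to compound 3 (0.04 log units; within the scatter) and a 1.2-fold lower number from compound 2 to compound 3 (0.08 log units; within the scatter) both fall inside the scatter, so no ordering among compounds 1, 2 and 3 can be read from them. Compound 4 `Cc1cc(-c2ccccc2)n(/C(N)=N/S(=O)(=O)c2cc(C)c(Cl)cc2SCc2ccc(Cl)cc2)n1` differs from compound 3 by 4-chlorophenyl in place of 3-methylphenyl on a saturated chain carbon bound to a sulfur. Going by the values given here, the only measured step at that position, a swap of the aryl group on the benzyl carbon, stayed within the scatter, and no measured step introduces a chlorine on this ring. The change to compound 4 is therefore expected to give a 1.0-fold higher number from compound 3 to compound 4 (0.01 log units; within the scatter), nothing beyond the scatter. Compound 4 is estimated at 0.22 h, ranging from 0.12 h to 0.4 h.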

Compound 4, half-life: 0.24 h
For compound 4 the middle estimate is 1.1-fold (0.04 log units) below the measured one, within the range that was stated.
By their numbers in this assay, from the lowest: compounds 3, 1, 4 and 2 (each within the scatter of the next).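

Working notes: in this assay a chlorine on the benzyl ring now has measured steps, with 4-chlorophenyl giving a 1.1-fold higher number from compound 3 to compound 4 (0.05 log units; within the scatter) and a 1.1-fold lower number from compound 2 to compound 4 (0.03 log units; within the scatter). 3-Methylphenyl, naphthalen-1-yl and 4-chlorophenyl on the saturated chain carbon bound to a sulfur therefore all stay within the scatter of one another in compounds 2, 3 and 4, and no aryl preference can be read at this place. No supporting evidence bears on this result.

Still open, from the compounds shown here alone, is whether an amine or a carboxylic acid on this ring, or a longer chain at this place, would move the half-life beyond the scatter.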